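A few compounds are considered here, and "the series" means these few. Any claim that something is new, unique, unknown or untested is made for them only; others in the source may bear on it.

Two measured compounds share one core and differ only in the group on a triple-bonded carbon. Compound 1 `CNC(=O)[C@@]12C[C@@H]1[C@@H](n1cnc3c(NC)nc(C#Cc4cccc(F)c4)nc31)[C@H](O)[C@@H]2O` gives 14% in an assay on CHO cells for displacement of a labelled ligand from adenosine receptor A1 (Homo sapiens), read by scintillation counting, with a stated time of 60 min, tested at 10 uM (on this read-out higher numbers stand for more inhibition at the one concentration tested (going by the name of the read-out) and lower numbers for less inhibition), while compound 2 `CCc1ccc(C#Cc2nc(NC)c3ncn([C@H]4[C@H](O)[C@H](O)[C@]5(C(=O)NC)C[C@H]45)c3n2)o1` gives 18% in this assay. Within the data shown here, the single step joining them, a number 4 percentage points higher from compound 1 to compound 2 (within the scatter), stays within the scatter, so the two values are read as the same. Compound 2 therefore stands at the top of two numbers only by a margin that means nothing, with compound 1 within the scatter beside it.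

Compound 3 `CNC(=O)[C@@]12C[C@@H]1[C@@H](n1cnc3c(NC)nc(C#CC4CCCCC4)nc31)[C@H](O)[C@@H]2O` is not yet measured. Its difference from compound 2 is cyclohexyl in place of 5-ethylfuran-2-yl on a triple-bonded carbon. Among the measured compounds shown here, the only step at hand, a number 4 percentage points higher from compound 1 to compound 2 (within the scatter), concerns a different exchange on the same triple-bonded carbon and was within the scatter, so no step beyond the scatter is expected here either; a change of about a number 3 percentage points lower from compound 2 to compound 3 (within the scatter) is estimated. Compound 3 is expected to give 15% in this assay, with a range from 0% to 35%.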

Compound 3, a percentage reported as inhibition, at one concentration (the size of the read-out at that concentration, not a potency): 15%
Compound 3: the middle estimate sits on the measured number at the digits printed; the range from low to high includes it.
By their numbers in this assay, from the lowest: compounds 1, 3 and 2 (each within the scatter of the next).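

With cyclohexyl on the triple-bonded carbon, a non-aromatic ring of carbon only joins the two aromatic groups, and the reading does not separate from theirs. In this assay the exchange for 5-ethylfuran-2-yl gives a number 3 percentage points lower from compound 2 to compound 3 (within the scatter) and the exchange for 3-fluorophenyl gives a number 1 percentage points higher from compound 1 to compound 3 (within the scatter), so all three compounds are read as the same, and neither the aromatic ring nor the oxygen of the furan shows any measurable weight at this position. No evidence is at hand that would account for this sameness.

The three groups shown are all uncharged and ring-bearing, so it remains open whether an amine, a carboxylic acid or a longer open alkyl chain on this carbon would move the number beyond the scatter. Whether any group here can do so also remains unsettled.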